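This account rests on a few compounds, and the source may have more. Where it says the series, first, only, none or still open, it means among the compounds named here.

Measured compounds in a physicochemical assay for lipophilicity, at pH 7.4; a higher number here means a more lipophilic compound, a lower number a more polar compound:

compound 1, `COc1ccc2[nH]c(C)c(Cc3ccccc3)c(=O)c2c1`: 2.53
compound 2, `COc1ccc2c(=O)c(Cc3ccccc3)c(C)[nH]c2c1`: 2.52
compound 3, `COc1ccc2c(c1)c(=O)c(Cc1ccccc1)c(C)n2C`: 2.73

Compound 1 and compound 2 are built from the same atoms joined differently; the difference between the two cores is not broken down here. Their values in this assay lie within the usual scatter of each other, so nothing separates them on this read-out.

Compound 3 stands to compound 1 as methyl in place of hydrogen on an aromatic nitrogen. The step is a number 0.20 log units higher from compound 1 to compound 3 (within the scatter), a small move that does not clear the scatter.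

Compound 4, `COc1ccc2c(=O)c(Cc3ccccc3)c(C)n(C)c2c1`, is not yet measured in this assay. It stands to compound 2 as methyl in place of hydrogen on an aromatic nitrogen, the same change as from compound 1 to compound 3, set on the other core. Within the data shown here, with only one measured instance of this change, the expectation rests on compound 1 and compound 3, where the step was a number 0.20 log units higher from compound 1 to compound 3 (within the scatter), and the estimated step from compound 2 to compound 4 is a number 0.20 log units higher from compound 2 to compound 4 (within the scatter). Compound 4 is thus expected to give about 2.72, roughly between 2.45 and 3.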

Compound 4, distribution coefficient: 3.24
Compound 4: middle estimate off by 0.52 log units, on the low side, outside the stated range (above it).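

In this assay methyl in place of hydrogen on an aromatic nitrogen gives a number 0.72 log units higher from compound 2 to compound 4 (beyond the scatter) while on the other core the same change gives a number 0.20 log units higher from compound 1 to compound 3 (within the scatter) so a step read on one core did not carry over in size to the other. With only these two instances, the series shows that this change cannot be transferred between the two cores at face value, but not which feature of the cores separates the steps or what the change would do on a further core. Nothing available bears on why the two steps differ.

Open, going by these compounds, is whether an ethyl group or a longer chain on the aromatic nitrogen would also give steps that differ between the two cores. Also open, on these data alone, is whether that difference would persist with an amine or a carboxylic acid in place of the benzyl group.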